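Chromone isoxazolidines: bromo in place of fluoro

The source may report more compounds than this note shows. Statements on the series, on what has been measured and on what is new or still open speak of the compounds shown alone.

The series shares a chromone-bearing core. Compound 1 `COC(=O)[C@H]1C[C@@H](c2coc3ccccc3c2=O)N(c2ccccc2)O1` carries a methoxycarbonyl on a saturated ring carbon; compound 2 `CCO[C@H]1C[C@@H](c2coc3ccccc3c2=O)N(c2ccccc2)O1` carries an ethoxy there. In a functional assay on Caco-2 cells (Homo sapiens) for inhibition, read by sulforhodamine B assay, with a stated time of 48 h (on this read-out higher numbers stand for weaker inhibition and lower numbers for stronger inhibition), compound 1 gives > 60000 nM, a limit of the assay and not a number. In this assay compound 2 gives > 60000 nM, again a limit. The step that the two limits leave unreadable from compound 1 to compound 2 therefore cannot be read. Compound 3 `O=C1[C@H]2[C@H](ON(c3ccccc3)[C@@H]2c2coc3ccc(F)cc3c2=O)C(=O)N1c1ccccc1`, with a fused imide on the core and a fluoro on the aromatic ring, gives in this assay the value > 60000 nM, once more a limit. Compound 3 thus stands where every value in the series stands, (the limit of > 60000 nM in this assay, at which 3 of the 3 values shown sit). Compound 4 `O=C1[C@H]2[C@H](ON(c3ccccc3)[C@@H]2c2coc3ccc(Br)cc3c2=O)C(=O)N1c1ccccc1` differs from compound 3 by bromo in place of fluoro on an aromatic carbon. Among the compounds with values here, no measured step touches the aromatic ring of the core, and the one recorded step is itself unreadable. The step expected in this assay is a step that the limit leaves unreadable from compound 3 to compound 4, of no readable size. Compound 4 is expected to give 80000 nM, between 30000 nM and 300000 nM, most likely again only a limit.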

Compound 4, half-maximal inhibitory concentration: 20300 nM
The estimate for compound 4 lay 3.9-fold (0.60 log units) above the measured number; the whole stated range lies above it.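

The aromatic carbon of the shared core is the only place among the compounds shown where a change gives a readable step: bromo in place of fluoro gives an at least 2.9-fold lower number from compound 3 to compound 4 (0.47 log units; beyond the scatter) in this assay, while the other step cannot be read. Compound 3 gives > 60000 nM, a limit and not a number, so the true step may be larger than the one printed. The change swaps one heavy atom for one heavy atom, with no ring, hydrogen-bond donor, hydrogen-bond acceptor or charge involved, yet compound 4 alone leaves the level shared by the others: the limit of > 60000 nM in this assay, at which 3 of the 4 values shown sit.

As far as these compounds go, whether chloro, methoxy or an amine on the same aromatic carbon would lower the number further stays open. Also open, from the compounds shown here alone, is whether bromo has any effect on the core of compound 1, without the fused imide.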